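A nitro group added to the phenoxy end of compound 1

A few compounds are considered here, and "the series" means these few. Any claim that something is new, unique, unknown or untested is made for them only; others in the source may bear on it.

Compound 1 `CC(C)[C@H](NC(=O)COc1cccc2ccccc12)C(=O)N[C@@H](CC(=O)O)C(=O)COc1ccccc1` gives 14000 nM in a functional assay on Jurkat cells (Homo sapiens); on this read-out lower numbers stand for stronger inhibition and higher numbers for weaker inhibition. Compound 2 `CC(C)[C@H](NC(=O)COc1cccc2ccccc12)C(=O)N[C@@H](CC(=O)O)C(=O)COc1cccc2ccccc12` reaches only the limit > 100000 nM. Compound 3 `CC(C)[C@H](NC(=O)COc1cccc2ccccc12)C(=O)N[C@@H](CC(=O)O)C(=O)COc1ccc(C(F)(F)F)cc1` likewise reaches only the limit > 100000 nM.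

For the measured compounds named here, compound 1 thus stands as the only compound with a true number; the other two sit at the limit of > 100000 nM in this assay, at which 2 of the 3 values shown sit. Compound 4 `CC(C)[C@H](NC(=O)COc1cccc2ccccc12)C(=O)N[C@@H](CC(=O)O)C(=O)COc1ccccc1[N+](=O)[O-]` differs from compound 1 by nitro in place of hydrogen on an aromatic carbon. Both measured steps also alter the phenoxy end: an at least 7.1-fold higher number from compound 1 to compound 2 (0.85 log units; beyond the scatter) and an at least 7.1-fold higher number from compound 1 to compound 3 (0.85 log units; beyond the scatter), each weakening inhibition beyond the scatter. A change at the same place is therefore expected to weaken inhibition again, giving an estimated 3.2-fold higher number from compound 1 to compound 4 (0.51 log units; beyond the scatter). Compound 4 is estimated at 45000 nM, with a range from 12000 nM to 150000 nM.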

Compound 4, half-maximal inhibitory concentration: > 100000 nM
Compound 4: a limit, no number; the forecaster's own chance of this, stated with the estimate: 40%; at least 2.2-fold (0.34 log units) between middle value and limit.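

Putting a 2-nitrophenyl group on the oxygen gives, in this assay, an at least 7.1-fold higher number from compound 1 to compound 4 (0.85 log units; beyond the scatter). Compound 4 reaches only a limit, > 100000 nM, not a number. For the compounds shown here, a third, different change to the phenoxy end therefore also weakens inhibition beyond the scatter, and compound 1 remains the only compound with a true number: the limit of > 100000 nM in this assay, at which 3 of the 4 values shown sit.

The steps among compound 2, compound 3 and compound 4 join limits and cannot be read. From the compounds shown here alone, whether a fluorine, a methyl group or an amine on this ring would keep a measurable number stays open.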